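Trimming the ring on the aromatic nitrogen

A few compounds are considered here, and "the series" means these few. Any claim that something is new, unique, unknown or untested is made for them only; others in the source may bear on it.

For the measured compounds named here, compound 1 `CCN1CCCC(n2cc(S(=O)(=O)c3ccccc3)c3ccccc32)C1` is the only member of this small set with a number attached. In a functional assay on HeLa cells for agonist activity at 5-hydroxytryptamine receptor 6 (Homo sapiens), read by cAMP accumulation and immunoassay, with a stated time of 10 min (a higher number here means that more compound is needed for the effect, a lower number that less compound is needed), compound 1 gives 31 nM, and it therefore stands alone as the sole reference point; compound 2 `COc1ccc2c(c1)c(S(=O)(=O)c1cccc(F)c1)cn2C1CCCN(C)C1` belongs to the same series but in this assay compound 2 gives "not determined" (no result reported), so nothing can be said of where it falls relative to compound 1.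

Compound 3 `O=S(=O)(c1ccccc1)c1cn(C2CCNC2)c2ccccc12` differs from compound 1 in a single place: pyrrolidin-3-yl in place of 1-ethylpiperidin-3-yl on an aromatic nitrogen. Going by the values given here, no pair of measured compounds in this set shows the effect of such a change, so the size of the step is open. The author expects a step of a 2.1-fold higher number from compound 1 to compound 3 (0.32 log units; beyond the scatter) in this assay that is modest and, if anything, toward a higher number for compound 3, although a result within the scatter of compound 1 would not be surprising. Compound 3 is accordingly estimated at 65 nM, with a likely range from 15 nM to 280 nM.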

Compound 3, half-maximal effective concentration: 60 nM
Compound 3: the middle estimate sits 1.1-fold (0.03 log units) above what was measured, within the range that was stated.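

In this assay, for the compounds shown here, the exchange of 1-ethylpiperidin-3-yl for pyrrolidin-3-yl on the aromatic nitrogen gives a 1.9-fold higher number from compound 1 to compound 3 (0.29 log units; within the scatter), the first measured step at this position, and the two compounds cannot be told apart in this read-out. The substituent here can therefore go from 8 heavy atoms to 5, from a six-membered to a five-membered ring, and gain a hydrogen-bond donor with no change in the number that exceeds the scatter, although the ring and the ethyl group differ together in this single step. No measurement is available that would account for this result.

The compounds shown leave open how piperidin-3-yl without the ethyl group or 1-ethylpyrrolidin-3-yl would read, and either would help separate the contribution of ring size from that of the ethyl group. Also open, on these data alone, is whether a longer, open chain ending in an amine, or a carboxylic acid, on this aromatic nitrogen would keep the value in the same range.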